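Compound 3 to compound 4: a smaller carbamate tail

The compounds below may be only part of what the source reports. "The series", "measured", "known", "first", "only" and "open" are said of these compounds alone.

Going by the values given here, in a physicochemical assay for solubility, in phosphate buffer, with a stated time of 18 h, at pH 7.4 (on this read-out lower numbers stand for lower solubility and higher numbers for higher solubility), compound 3 `COc1cc2ncnc(-n3nc(-c4ccccn4)nc3N)c2cc1OCCCCNC(=O)OC(C)(C)C` gives 500 nM, the lowest number so far. Compound 2 `COCCOc1cc2c(-n3nc(-c4ccccn4)nc3N)ncnc2cc1OC` gives 8000 nM, and compound 1 `COc1cc2ncnc(-n3nc(-c4ccccn4)nc3N)c2cc1OCCCN(C)C` gives 53000 nM.

The next compound is compound 4 `CCOC(=O)NCCCOc1cc2c(-n3nc(-c4ccccn4)nc3N)ncnc2cc1OC`, and the change is (ethoxycarbonyl)amino in place of ((tert-butoxycarbonyl)amino)methyl on a saturated chain carbon, three bonds along the chain from an oxygen on an aromatic ring. Neither group has a ring or a net charge.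

Among the compounds with values here, three measured steps bear on this only indirectly. The largest is a 110-fold lower number from compound 1 to compound 3 (2.03 log units; beyond the scatter), followed by a 16-fold lower number from compound 2 to compound 3 (1.20 log units; beyond the scatter), and both end on the tert-butoxycarbonyl compound. The third, a 6.6-fold lower number from compound 1 to compound 2 (0.82 log units; beyond the scatter), is modest and involves no carbamate. Within the data shown here, none of them exchanges one carbamate for another, so the series offers no direct precedent for this change.

Compound 4 keeps a carbamate, as does compound 3 at 500 nM, so the large steps seen on replacing dimethylamino or methoxy are not expected to be repeated in full. A small rise is the expectation, though one within the scatter cannot be excluded, and the estimated step is a 2.4-fold higher number from compound 3 to compound 4 (0.38 log units; beyond the scatter). The estimated value for compound 4 is 1200 nM, with an expected range of 300 nM to 5000 nM.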

Compound 4, solubility: 16000 nM
The estimate for compound 4 lay 13-fold (1.12 log units) below the measured number; measured number above the stated range.
By their numbers in this assay, from the lowest: compound 3; then compounds 2 and 4 (each within the scatter of the next); then compound 1.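

In this assay the carbamate alone does not fix the number at this position: a 32-fold higher number from compound 3 to compound 4 (1.51 log units; beyond the scatter) is a large step, although both compounds carry one, so the two carbamate tails are not interchangeable here. The ethyl carbamate tail instead falls in with the other tails, with a 2.0-fold higher number from compound 2 to compound 4 (0.30 log units; within the scatter) leaving compound 4 and compound 2 undistinguished, while a 3.3-fold lower number from compound 1 to compound 4 (0.52 log units; beyond the scatter) is a modest step that still separates the dimethylamino tail from the carbamate. No measurement among these compounds accounts for the large gap between the two carbamates.

This change replaces 4-((tert-butoxycarbonyl)amino)butyl with 3-((ethoxycarbonyl)amino)propyl, so the shorter chain and the exchange of tert-butyl for ethyl arrive together, and the compounds shown leave open how much of the step belongs to each; a 3-((tert-butoxycarbonyl)amino)propyl or a 4-((ethoxycarbonyl)amino)butyl tail on the same core would separate the two. Also open, from the compounds shown here alone, is where a primary amine or a carboxylic acid at the end of the same chain would stand against the dimethylamino tail of compound 1.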